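Adding a 4-bromobenzyl Group: Expected Cytotoxicity of Compound 4

This account rests on a few compounds, and the source may have more. Where it says the series, first, only, none or still open, it means among the compounds named here.

Compound 1 `Cc1c(Cc2ccccc2)c(=O)oc2cc(OCC(O)CNCC3CC3)ccc12`: in an ADME assay on A549 cells (Homo sapiens) for cytotoxicity, read by CellTiter-Glo (a higher number here means that more compound is tolerated, a lower number that less compound is tolerated), compound 1 gives > 100000 nM, a limit of the assay.
Compound 2 `Cc1c(Cc2ccccc2)c(=O)oc2cc(OCC(O)CNCc3ccccc3)ccc12`: in this assay compound 2 gives > 100000 nM, also a limit.
Compound 3 `Cc1cc(=O)oc2cc(OCC(O)CN3CCC(C(N)=O)CC3)ccc12`: in this assay compound 3 gives > 100000 nM, again a limit.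

Compound 3 thus stands at the limit of > 100000 nM in this assay, at which 3 of the 3 values shown sit. Compound 4 `Cc1c(Cc2ccc(Br)cc2)c(=O)oc2cc(OCC(O)CN3CCC(C(N)=O)CC3)ccc12` differs from it by 4-bromobenzyl in place of hydrogen on an aromatic carbon. For the measured compounds named here, the only measured step, a step that the two limits leave unreadable from compound 1 to compound 2, concerns a different change and remains unreadable between two limits, so it offers no readable size for the present change. With every value shown sitting at the limit, no shift beyond the scatter is expected for compound 4, and a number no higher from compound 3 to compound 4 (the limit leaves the size open) is estimated as essentially nil. Compound 4 is therefore expected to give 100000 nM in this assay, within 30000 nM to 300000 nM, most likely reported again as a limit.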

Compound 4, half-maximal cytotoxic concentration: > 100000 nM
Compound 4 was reported as a limit; the forecaster's own chance of this, stated with the estimate: 75%; the middle value lies on the limit itself.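

In this assay compound 3 and compound 4 are both reported as limits, so no step can be read between them. The compounds shown leave open whether 4-bromobenzyl in place of hydrogen changes cytotoxicity at all, and where any true value lies: the limit of > 100000 nM in this assay, at which 4 of the 4 values shown sit.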